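A few compounds are considered here, and "the series" means these few. Any claim that something is new, unique, unknown or untested is made for them only; others in the source may bear on it.

Four compounds share one core and are compared in an assay on cells (Hepatocyte) for inhibition of glucokinase regulatory protein (Mus musculus), with stated times of 20 min and 40 min; a higher number here means that more compound is needed for the effect, a lower number that less compound is needed: compound 1 `CC#C[C@H]1CN(S(=O)(=O)c2ccc(N)nc2)CCN1c1ccc(C(C)(O)C(F)(F)F)nc1`, compound 2 `CC#C[C@H]1CN(S(=O)(=O)c2ccc(N)nc2)CCN1c1ccc(S(=O)(=O)Nc2ccccc2)cc1`, compound 3 `CC#C[C@H]1CN(S(=O)(=O)c2ccc(N)nc2)CCN1c1ncc(C(O)(C(F)(F)F)C(F)(F)F)s1` and the not yet measured compound 4 `CC#C[C@H]1CN(S(=O)(=O)c2ccc(N)nc2)CCN1c1ccc([S+](C)[O-])cc1`. Compound 1 gives 1450 nM in this assay. For compound 2 this assay returns only a limit, > 12500 nM, and not a number. For compound 3 this assay likewise returns only a limit, > 12500 nM. As far as these compounds go, compound 2 therefore stands at the limit of > 12500 nM in this assay, at which 2 of the 3 values shown sit, so where it truly lies above that line is unknown.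

Compound 4 differs from compound 2 in one place: a group of 3 heavy atoms (1 carbon, 1 oxygen, 1 sulfur; no ring) in place of a group of 10 heavy atoms (6 carbon, 1 nitrogen, 2 oxygen, 1 sulfur; one six-membered aromatic ring of carbon only), on an aromatic carbon. Among the compounds with values here, no two measured compounds differ in a single place, so no measured step shows how such a swap plays out. The expectation for compound 4 is nonetheless that less compound is needed than the reading for compound 2 suggests, because compound 1 reaches 1450 nM in this assay while carrying its own different group on the shared core. Compound 4 is estimated at 4000 nM, with a range from 1000 nM to 15000 nM. That estimate means an expected step of an at least 3.1-fold lower number from compound 2 to compound 4 (0.49 log units; beyond the scatter), pointing towards less compound being needed, though a further limit rather than a number remains a real possibility.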

Compound 4, half-maximal effective concentration: > 12500 nM
Compound 4 ended at the assay's limit; the forecaster's own chance of this, stated with the estimate: 35%; middle value at least 3.1-fold (0.49 log units) away from the limit.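

Within the data shown here, compound 2 and compound 4 both stop at a limit rather than a number, so no step between them can be read in this assay: the limit of > 12500 nM in this assay, at which 3 of the 4 values shown sit. The compounds shown leave open how far past that limit either compound truly lies, and whether replacing phenylsulfamoyl with the smaller group changes how much compound is needed.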